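A few compounds are considered here, and "the series" means these few. Any claim that something is new, unique, unknown or untested is made for them only; others in the source may bear on it.

Compound 1, `c1ccc(-c2nc3cccnc3o2)cc1`, gives 55% in a functional assay on the whole organism for inhibition, with Rattus norvegicus as the target, at a dose of 30 mg/kg; on this read-out lower numbers stand for less inhibition and higher numbers for more inhibition at the one dose given (going by the name of the read-out). Within the data shown here, compound 2, `Clc1ccc(-c2nc3cccnc3o2)cc1`, gives 14% in this assay, so the single measured step, a number 41 percentage points lower from compound 1 to compound 2 (beyond the scatter), is a large fall. Among the measured compounds shown here, compound 2 therefore stands lowest of the two measured numbers, with compound 1 the only neighbour, sitting well above it.

Compound 3, `N#Cc1ccc(-c2nc3cccnc3o2)cc1`, is the next member, and it differs from compound 2 at one place only: cyano in place of chloro on an aromatic carbon. For the measured compounds named here, the one measured step that bears on this change is the one from compound 1 to compound 2, in which a chloro group entering on the aromatic carbon brought the read-out down by a large amount. That step shows the read-out reacts strongly to a substituent at this carbon, but it does not show whether cyano will behave like chloro or like hydrogen. A return toward the number of compound 1 is as plausible as staying near compound 2, so the expectation is a moderate rise with wide uncertainty. Compound 3 is expected to give 30% in this assay, between 5% and 60%, which is an expected step of a number 16 percentage points higher from compound 2 to compound 3 (beyond the scatter).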

Compound 3, a percentage reported as inhibition, in the whole organism at one dose (the size of the read-out at that dose, not a potency): 17%
Beside the measured number, compound 3's estimate is 13 percentage points above it, within the range that was stated.
By their numbers in this assay, from the lowest: compounds 2 and 3 (each within the scatter of the next); then compound 1.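

In this assay, replacing chloro with cyano gives a number 3 percentage points higher from compound 2 to compound 3 (within the scatter), so on this read-out the two groups cannot be told apart on this aromatic carbon, para to a group of 9 heavy atoms. Measured against the hydrogen of compound 1, cyano gives a number 38 percentage points lower from compound 1 to compound 3 (beyond the scatter), a large fall like a number 41 percentage points lower from compound 1 to compound 2 (beyond the scatter), which shows that the low read-out is not confined to chloro but appears with both groups placed here, even though cyano has more heavy atoms and carries a hydrogen-bond acceptor that chloro lacks. Nothing measured here accounts for the fall or for the match between the two groups.

On these data alone, it remains open whether every group on this carbon lowers the read-out or only these two, and an amine, a methoxy group or a carboxylic acid in the same place could fall near compound 1 or near compound 2 and compound 3. As far as these compounds go, the read-out also comes from a single dose, so whether compound 2 and compound 3 would still match at other doses stays open.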